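A few compounds are considered here, and "the series" means these few. Any claim that something is new, unique, unknown or untested is made for them only; others in the source may bear on it.

Compound 3 `COc1cc(-c2cc(C(=O)O)c3ccccc3n2)ccc1OCC(=O)Nc1cccc(F)c1` stands at the top of the three numbers in a physicochemical assay for lipophilicity, using the shake flask method, in phosphate buffer, measured as octanol-water partition, at pH 7.4 (a higher number here means a more lipophilic compound, a lower number a more polar compound), where compound 3 gives 1.6. Compound 1 `COc1cc(-c2cc(C(=O)O)c3ccccc3n2)ccc1OCC(=O)Nc1cccc(C)c1` gives 1.5, and the step of a number 0.10 log units higher from compound 1 to compound 3 (within the scatter) stays within the scatter. Compound 2 `COc1cc(-c2cc(C(=O)O)c3ccccc3n2)ccc1OCC(=O)Nc1ccccc1F` gives 0.9, and the step of a number 0.70 log units higher from compound 2 to compound 3 (beyond the scatter) lies beyond it. Compound 4 `COc1cc(-c2cc(C(=O)O)c3ccccc3n2)ccc1OCC(=O)Nc1ccccc1Cl` carries the change (2-chlorophenyl in place of 3-fluorophenyl on an amide-type nitrogen). Going by the values given here, two measured steps bear on it: a number 0.70 log units higher from compound 2 to compound 3 (beyond the scatter) and a number 0.60 log units lower from compound 1 to compound 2 (beyond the scatter), each a modest shift when a 2-fluorophenyl stands against another substituted phenyl. Among the compounds with values here, no measured step sets chloro against fluoro on this ring. The step from compound 3 is therefore estimated as a number 0.40 log units lower from compound 3 to compound 4 (beyond the scatter), a modest move downward in this assay. Compound 4 is expected to give about 1.2, between 0.7 and 1.7.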

Compound 4, distribution coefficient: 1.6
For compound 4 the middle estimate is 0.40 log units below the measured one; measured number inside the range.
By their numbers in this assay, from the lowest: compound 2; then compounds 1, 3 and 4 (each within the scatter of the next).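

On the amide-type nitrogen in this assay, 2-chlorophenyl against 3-fluorophenyl gives no change at the digits printed from compound 3 to compound 4 (within the scatter) and against 3-methylphenyl gives a number 0.10 log units higher from compound 1 to compound 4 (within the scatter), so compounds 1, 3 and 4 cannot be told apart here. Chloro in place of fluoro on the aromatic carbon gives a number 0.70 log units higher from compound 2 to compound 4 (beyond the scatter) and shows that the low number of compound 2 is not shared by the 2-chlorophenyl of compound 4. Nothing given here accounts for this gap. The compounds shown leave open whether 2-methylphenyl or 2-methoxyphenyl on this nitrogen would stand with compound 2 or with the other three. They also leave open how 3-chlorophenyl would compare with 3-fluorophenyl.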